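This account rests on a few compounds, and the source may have more. Where it says the series, first, only, none or still open, it means among the compounds named here.

Compound 1, `Cc1ccc2c(c1)C1(C(=O)N2C)C(C#N)=C(N)Oc2cc3oc(-c4ccccc4)cc(=O)c3c(O)c21`. In a functional assay on PC-3 cells (Homo sapiens) for antiproliferative activity, read by MTT assay, with a stated time of 48 h (on this read-out higher numbers stand for weaker inhibition and lower numbers for stronger inhibition), compound 1 gives only a limit, > 50000 nM.
Compound 2, `CN1C(=O)C2(C(C#N)=C(N)Oc3cc4oc(-c5ccccc5)cc(=O)c4c(O)c32)c2cc(Br)ccc21`. In this assay compound 2 gives 20300 nM.
Compound 3, `Cc1ccc2c(c1)C1(C(=O)N2Cc2ccccc2)C(C#N)=C(N)Oc2cc3oc(-c4ccccc4)cc(=O)c3c(O)c21`. In this assay compound 3 gives only a limit, > 50000 nM.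

Compound 3 therefore stands at the limit of > 50000 nM in this assay, at which 2 of the 3 values shown sit, so its true value is not known, only that it lies beyond that limit. The move to compound 4, `COc1ccc2c(c1)C1(C(=O)N2Cc2ccccc2)C(C#N)=C(N)Oc2cc3oc(-c4ccccc4)cc(=O)c3c(O)c21`, is methoxy in place of methyl on an aromatic carbon.

Two measured steps exist. The first, an at least 2.4-fold lower number from compound 1 to compound 2 (0.39 log units; beyond the scatter), changes the same aromatic carbon but puts in bromo, not methoxy, so it speaks only indirectly to the present change. The second, a step that the two limits leave unreadable from compound 1 to compound 3, concerns another place and its size cannot be read, since both ends sit at a limit. Going by the values given here, no measured step follows methyl giving way to methoxy, and the starting point itself is a limit.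

Compound 4 is therefore expected to remain weak in this assay, at about 50000 nM, within 15000 nM to 150000 nM. That amounts to an expected step of a number no higher from compound 3 to compound 4 (the limit leaves the size open), which cannot be called a change beyond the scatter, and a limit rather than a number is the more likely report for compound 4.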

Compound 4, half-maximal inhibitory concentration: > 50000 nM
Compound 4: only a limit was reported; the forecaster's own chance of this, stated with the estimate: 60%; the middle value lies on the limit itself.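

Going by these compounds alone, compound 3 and compound 4 both give only a limit rather than a number, so no step between them can be read: the limit of > 50000 nM in this assay, at which 3 of the 4 values shown sit. The compounds shown leave open whether methoxy in place of methyl on an aromatic carbon changes the true value in this assay at all.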